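A fluoro-to-methoxy swap on a fluorinated benzothiazole core

A few compounds are considered here, and "the series" means these few. Any claim that something is new, unique, unknown or untested is made for them only; others in the source may bear on it.

Measured compounds:
compound 1, `Cc1ccc(-c2ccc(F)cc2)n1-c1ccc(-c2nc3ccccc3s2)cc1`: 11800 nM
compound 2, `COc1ccc(-c2ccc(C)n2-c2ccc(-c3nc4ccccc4s3)cc2)cc1`: 14800 nM
compound 3, `Cc1ccc(-c2ccc(F)cc2)n1-c1ccc(-c2nc3ccc(F)cc3s2)cc1`: 14100 nM

In a functional assay on MDA-MB-231 cells (Homo sapiens) for cytotoxicity, read by MTT assay, with a stated time of 72 h (a higher number here means a weaker inhibitor, a lower number a stronger inhibitor), compound 1 gives 11800 nM. Compound 2 differs by methoxy in place of fluoro on an aromatic carbon, and this change produced a 1.3-fold higher number from compound 1 to compound 2 (0.10 log units; within the scatter). Compound 3 differs from compound 1 by fluoro in place of hydrogen on an aromatic carbon, which gave a 1.2-fold higher number from compound 1 to compound 3 (0.08 log units; within the scatter). The unmeasured compound 4, `COc1ccc(-c2ccc(C)n2-c2ccc(-c3nc4ccc(F)cc4s3)cc2)cc1`, carries methoxy in place of fluoro on an aromatic carbon, the same change as that from compound 1 to compound 2, made on the core of compound 3. Because the earlier step was a 1.3-fold higher number from compound 1 to compound 2 (0.10 log units; within the scatter), compound 4 is expected to show a step of similar size, a 1.3-fold higher number from compound 3 to compound 4 (0.11 log units; within the scatter), in this assay. The estimate for compound 4 is therefore 18000 nM, with a range from 9000 nM to 36000 nM expected.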

Compound 4, half-maximal inhibitory concentration: 19000 nM
Beside the measured number, compound 4's estimate is 1.1-fold (0.02 log units) below it; low and high end bracket the measured number.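

In this assay, methoxy in place of fluoro gave a 1.3-fold higher number from compound 3 to compound 4 (0.13 log units; within the scatter), and this step agrees with the one on the other core: the same change on two cores in this assay, a 1.3-fold higher number (0.10 log units; within the scatter) from compound 1 to compound 2 and a 1.3-fold higher number (0.13 log units; within the scatter) from compound 3 to compound 4, 1.1-fold (0.03 log units) apart, within the scatter of two such steps

Fluoro in place of hydrogen on an aromatic carbon gave a 1.3-fold higher number from compound 2 to compound 4 (0.11 log units; within the scatter), and this step also agrees with its counterpart: the same change on two cores in this assay, a 1.2-fold higher number (0.08 log units; within the scatter) from compound 1 to compound 3 and a 1.3-fold higher number (0.11 log units; within the scatter) from compound 2 to compound 4, 1.1-fold (0.03 log units) apart, within the scatter of two such steps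

Among the compounds shown here, all of these steps lie within the scatter, so the agreement shows only that neither change gave a step beyond the scatter on these cores; it does not show that a real effect carries from one core to another.

The compounds shown leave open whether an amine or a carboxylic acid in place of the fluoro or methoxy would give a step beyond the scatter. They also leave open whether such a step would hold on both cores.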